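Cytotoxicity of chalcone amides on Vero cells

The source may hold more compounds than are shown below. What is called first, only, known or untested is meant among the compounds shown, and "the series" means these compounds.

Measured compounds:
compound 1 `COC(=O)c1cc(-c2cccc(NC(=O)c3ccc(/C=C/C(=O)c4ccc(C)cc4)cc3)c2)on1`: > 80 ug/mL
compound 2 `COC(=O)c1cc(-c2cccc(NC(=O)c3ccc(/C=C/C(=O)c4cccnc4)cc3)c2)on1`: "not determined" (no result reported)

Compound 1 reaches only a limit of an ADME assay on Vero cells (Chlorocebus sabaeus) for cytotoxicity, read by MTT assay, with a stated time of 72 h (a higher number here means that more compound is tolerated, a lower number that less compound is tolerated), > 80 ug/mL. The evidence on hand is the limit of > 80 ug/mL in this assay, at which 1 of the 2 values shown sits. For compound 2 this assay gives "not determined" (no result reported), so no number places it. Compound 3 `COC(=O)c1cc(-c2cccc(NC(=O)c3ccc(/C=C/C(=O)c4ccccc4Cl)cc3)c2)on1` differs from compound 2 by 2-chlorophenyl in place of pyridin-3-yl on a carbonyl carbon. For the measured compounds named here, with no measured step to lean on, no shift beyond the scatter is expected in this assay. Compound 3 is expected to sit near 80 ug/mL, in the range 30 ug/mL to 160 ug/mL, most likely again as a limit.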

Compound 3, half-maximal cytotoxic concentration: > 25 ug/mL
Compound 3: a limit, no number; the forecaster's own chance of this, stated with the estimate: 70%; the middle value lies beyond the limit too.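

Compound 1 and compound 3 both give only limits in this assay, so the step between them cannot be read. Going by these compounds, whether 2-chlorophenyl and 4-methylphenyl on a carbonyl carbon differ at all in this assay remains open, as does where compound 2 stands.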